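Swapping Trifluoromethyl for Nitro on a Shared Core

A few compounds are considered here, and "the series" means these few. Any claim that something is new, unique, unknown or untested is made for them only; others in the source may bear on it.

compound 1 `Nc1nc(N)nc(-c2cc(C(F)(F)F)ccc2Cl)n1`: 2.27
compound 2 `Nc1nc(N)nc(-c2cccc(C(F)(F)F)c2)n1`: 2.67
compound 3 `CCCNc1c(C)n(-c2ccccc2)c(=O)n(C)c1=O`: 1.7

In a physicochemical assay for lipophilicity (on this read-out higher numbers stand for higher lipophilicity and lower numbers for lower lipophilicity), compound 2 gives the highest of the three numbers. The nearest measured compound is compound 1, separated by the step of a number 0.40 log units higher from compound 1 to compound 2 (beyond the scatter), which came from hydrogen in place of chloro on an aromatic carbon. Compound 3 lies furthest away, with 1.7 in this assay.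

Compound 4 `Nc1nc(N)nc(-c2cccc([N+](=O)[O-])c2)n1` differs from compound 2 as follows: nitro in place of trifluoromethyl on an aromatic carbon. Going by the values given here, none of the measured steps involves a nitro or a trifluoromethyl group, so no measured step bears directly on this change; the only measured step concerns a chloro. The expectation is nevertheless a downward step, a number 1.17 log units lower from compound 2 to compound 4 (beyond the scatter). Compound 4 is estimated at 1.5, within the range 1.1 to 1.9.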

Compound 4, partition coefficient: 1.57
For compound 4 the middle estimate is 0.07 log units below the measured one, and the stated range covers the measured number.
By their numbers in this assay, from the lowest: compounds 4 and 3 (each within the scatter of the next); then compound 1; then compound 2.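

On the shared core, nitro in place of trifluoromethyl on this aromatic carbon gives a number 1.10 log units lower from compound 2 to compound 4 (beyond the scatter) in this assay. Going by these compounds alone, the only earlier step was modest and concerned a chloro, so this is the first sign that the group on this carbon can move the number by a large amount. No measurement shown explains the size of this drop.

As far as these compounds go, whether a nitrile or a carboxylic acid on the same carbon would fall nearer compound 2 or compound 4 remains open, as does whether this swap gives a similar step when the chloro of compound 1 is present.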